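This account rests on a few compounds, and the source may have more. Where it says the series, first, only, none or still open, it means among the compounds named here.

Measured in a functional assay with Homo sapiens as the target; on this read-out lower numbers stand for stronger inhibition and higher numbers for weaker inhibition:
- compound 1 `CC(C)[C@H](NC(=O)COc1cccc2ccccc12)C(=O)N[C@@H](CC(=O)O)C(=O)COc1ccccc1`: 11200 nM
- compound 2 `CC(C)[C@H](NC(=O)COc1cccc2ccccc12)C(=O)N[C@@H](CC(=O)O)C(=O)COc1ccc(-c2ccccc2)cc1`: 38700 nM
- compound 3 `CC(C)[C@H](NC(=O)COc1cccc2ccccc12)C(=O)N[C@@H](CC(=O)O)C(=O)COc1ccc(C#N)cc1`: 26700 nM

Compound 3 is second highest of the three numbers. The steps that place it are a 1.4-fold lower number from compound 2 to compound 3 (0.16 log units; within the scatter) and a 2.4-fold higher number from compound 1 to compound 3 (0.38 log units; beyond the scatter).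

The next analogue is compound 4 `CC(C)[C@H](NC(=O)COc1cccc2ccccc12)C(=O)N[C@@H](CC(=O)O)C(=O)COc1ccc(Oc2ccccc2)cc1`, which carries phenoxy in place of cyano on an aromatic carbon.

The closest measured precedent is the phenyl change, a 3.5-fold higher number from compound 1 to compound 2 (0.54 log units; beyond the scatter). It is modest, and the same holds for the cyano change from hydrogen. Within the data shown here, both substituted compounds therefore give higher numbers than compound 1, with no compound here going against that. Phenoxy also brings a six-membered aromatic ring, so compound 2, at 38700 nM, is the best guide, though no measured compound carries phenoxy itself. Little movement is therefore expected from the change of substituent, and any shift should be slightly upward.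

The expected size of the change is a 1.2-fold higher number from compound 3 to compound 4 (0.08 log units; within the scatter).

For compound 4 the estimated value is 32000 nM, with an expected range of 15000 nM to 70000 nM.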

Compound 4, half-maximal inhibitory concentration: 19000 nM
Compound 4: middle estimate off by 1.7-fold (0.23 log units), on the high side, within the range that was stated.
By their numbers in this assay, from the lowest: compounds 1, 4, 3 and 2 (each within the scatter of the next, the first and the last beyond it).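

In this assay, a six-membered aromatic ring on this aromatic carbon does not fix the read-out: the phenoxy and phenyl compounds differ beyond the scatter (a 2.0-fold lower number from compound 2 to compound 4 (0.31 log units; beyond the scatter)), so attachment through oxygen separates two substituents that both carry that ring. Phenoxy is also the first substituent here that stays within the scatter of the unsubstituted compound, and it cannot be told apart from cyano either (a 1.7-fold higher number from compound 1 to compound 4 (0.23 log units; within the scatter); a 1.4-fold lower number from compound 3 to compound 4 (0.15 log units; within the scatter)). No supporting measurement is available to account for these differences.

The compounds shown leave open how an amine or a carboxylic acid would read out at this same place. They also leave open whether a longer chain between the oxygen and the aromatic ring would stay within the scatter of phenoxy.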